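From benzyloxy to phenoxy: a small swap

A few compounds are considered here, and "the series" means these few. Any claim that something is new, unique, unknown or untested is made for them only; others in the source may bear on it.

Compound 1 `NS(=O)(=O)c1ccc(N2N=C(c3ccc(OCc4ccccc4)cc3)CC2c2ccccc2)cc1`: > 100000 nM (a limit)
Compound 2 `NS(=O)(=O)c1ccc(N2N=C(c3ccc(OCc4ccccc4)cc3)CC2c2ccc(F)cc2)cc1`: 90000 nM

In an ADME assay on Vero 76 cells (Chlorocebus sabaeus) for cytotoxicity, read by MTT assay, with a stated time of 96 h (a higher number here means that more compound is tolerated, a lower number that less compound is tolerated), compound 1 stands at > 100000 nM as a limit of the assay and not a number. Compound 3 `NS(=O)(=O)c1ccc(N2N=C(c3ccc(Oc4ccccc4)cc3)CC2c2ccccc2)cc1` differs from it by one swap phenyl in place of benzyl on an oxygen on an aromatic ring with phenyl in place of benzyl on an oxygen on an aromatic ring. Among the compounds with values here, the one measured step is an at least 1.1-fold lower number from compound 1 to compound 2 (0.04 log units; that floor lies within the scatter) and it is a different change, so no step beyond the scatter is expected here in this assay for this swap. The expected step is an at least 1.1-fold lower number from compound 1 to compound 3 (0.04 log units; that floor lies within the scatter) on this reasoning. Compound 3 is estimated at 90000 nM with an expected range of 40000 nM to 100000 nM for its value.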

Compound 3, half-maximal cytotoxic concentration: 85000 nM
Beside the measured number, compound 3's estimate is 1.1-fold (0.02 log units) above it, and the stated range covers the measured number.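

Replacing benzyl with phenyl on the oxygen is the first change shown at this position, and in this assay it gives an at least 1.1-fold lower number from compound 1 to compound 3 (0.07 log units; that floor lies within the scatter). Compound 3 reads 85000 nM, so the phenoxy compound, like compound 2, has a measured number in this assay. The true size of this step cannot be read because compound 1 carries a limit and not a number: the limit of > 100000 nM in this assay, at which 1 of the 3 values shown sits.

Going by these compounds, whether a longer chain or an amine in place of benzyl on the oxygen would shift the number beyond the scatter stays open.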